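This account rests on a few compounds, and the source may have more. Where it says the series, first, only, none or still open, it means among the compounds named here.

Series notes. Compound 1 `COc1ccc(-c2csc(=S)[nH]2)cc1` has the higher of the two measured numbers: in an assay on isolated protein for inhibition of Indoleamine 2,3-dioxygenase 1 (Homo sapiens), read by colorimetric assay, with stated times of 10 min and 30 min, tested at 100 uM (on this read-out higher numbers stand for more inhibition at the one concentration tested (going by the name of the read-out) and lower numbers for less inhibition), compound 1 gives 68%, while compound 2 `S=c1[nH]c(-c2cccc(Cl)c2)cs1` gives 40% in this assay, a gap beyond the scatter. Compound 3 `FC(F)(F)c1ccc(-c2csc(=S)[nH]2)cc1` has not yet been run in this assay. It differs from compound 1 by trifluoromethyl in place of methoxy on an aromatic carbon. For the measured compounds named here, no measured pair isolates this change, so the size of the step is uncertain; a moderate drop from compound 1 is expected, since compound 2 40% shows that changing the aryl substituent can lower the inhibition read in this assay, with the expected step of a number 18 percentage points lower from compound 1 to compound 3 (beyond the scatter). Compound 3 is thus estimated at 50%, within 25% to 75%.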

Compound 3, a percentage reported as inhibition, at one concentration (the size of the read-out at that concentration, not a potency): 37%
Beside the measured number, compound 3's estimate is 13 percentage points above it, and the stated range covers the measured number.
By their numbers in this assay, from the lowest: compounds 3 and 2 (each within the scatter of the next); then compound 1.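

Trifluoromethyl in place of methoxy on this aromatic carbon gives the series its first step that differs in one place: a number 31 percentage points lower from compound 1 to compound 3 (beyond the scatter) in this assay. This shows that the read-out at this position depends on the group carried there, with methoxy giving more inhibition than trifluoromethyl. No measurement on hand bears on the reason for this step.

Going by these compounds, whether a hydroxyl, an amine or a longer chain such as ethoxy on this carbon would match compound 1 remains open. With only two groups compared here, the compounds shown give no trend across substituents at this position.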